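The compounds below may be only part of what the source reports. "The series", "measured", "known", "first", "only" and "open" are said of these compounds alone.

Working notes on the series in a functional assay on NCI-H292 cells (Homo sapiens) for cytotoxicity, read by MTT assay, with a stated time of 72 h, tested at 1.25 ug/mL; a lower number here means less inhibition of growth, a higher number more inhibition of growth at the concentration tested.

Compound 3 `O=C1NC(=S)/C(=C/c2ccccc2Cl)S1` gives 10.6% in this assay. Among the three measured numbers it sits in the middle, with compound 1 `O=C1NC(=S)/C(=C/c2ccc(Cl)cc2)S1`, which gives 10%, on one side, and compound 2 `O=C1NC(=S)/C(=C/c2ccccc2Br)S1`, which gives 13.3%, on the other; both gaps are within the scatter, so the three compounds cannot be ordered.

Compound 4 `O=C1NC(=S)/C(=C/c2ccc(Cl)cc2Cl)S1` differs from compound 3 by chloro in place of hydrogen on an aromatic carbon. Among the compounds with values here, the only measured step that bears on an aromatic halogen change is a number 2.7 percentage points lower from compound 2 to compound 3 (within the scatter), and that swap of one halogen for another left the number where it was. Within the data shown here, no measured pair shows the effect of a second chloro on the same ring, so the expectation rests on the flatness of the three numbers so far.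

The step of a number 0.4 percentage points higher from compound 3 to compound 4 (within the scatter) is therefore expected to stay inside the scatter. For compound 4 the estimate in this assay is 11%, with a range from 2% to 22%.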

Compound 4, percent growth inhibition at one concentration: 12.1%
Compound 4: the middle estimate sits 1.1 percentage points below what was measured; the range from low to high includes it.
By their numbers in this assay, from the lowest: compounds 1, 3, 4 and 2 (each within the scatter of the next).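

The second chloro can now be read from both sides in this assay: a number 1.5 percentage points higher from compound 3 to compound 4 (within the scatter) and a number 2.1 percentage points higher from compound 1 to compound 4 (within the scatter). On compound 3, a chloro that enters meta to a chloro group and para to a group of 8 heavy atoms therefore gives no readable change, and the same holds for the chloro added to compound 1, so a second chloro on this ring leaves the number within the scatter from either single-chloro compound. No measurement at hand offers an explanation for these two steps.

Every substituent shown on the ring is a halogen, so it remains open whether an amine, a carboxylic acid or a methoxy group would move the number beyond the scatter. On these data alone, it also remains open whether these compounds would separate at any other concentration.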